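The source may report more compounds than this note shows. Statements on the series, on what has been measured and on what is new or still open speak of the compounds shown alone.

Measured compounds:
compound 1, `CC(C)c1cccc(OCc2cccc(N3C(N)=NC(N)=NC3(C)C)c2)c1`: 8.13
compound 2, `CC1(C)N=C(N)N=C(N)N1c1cccc(C(O)c2ccccc2)c1`: 6.41
compound 3, `CC1(C)N=C(N)N=C(N)N1c1cccc(OCCOc2ccccc2)c1`: 7.34

All three share one core and were tested in a functional assay on L5178Y cells (Mus musculus) for inhibition; a higher number here means a more potent compound, by a factor of ten per unit of this negative logarithm, a lower number a less potent compound. Compound 2 stands lowest of the three: compound 3 is higher by a margin beyond the usual scatter, and compound 1 is higher still. Compound 4, `CC1(C)N=C(N)N=C(N)N1c1cccc(F)c1`, has not yet been measured; it differs from compound 2 in one place: fluoro in place of hydroxy(phenyl)methyl on an aromatic carbon. The change puts a single small atom where a larger group with one donor and one acceptor stood, on an aromatic carbon, meta to a large group. Within the data shown here, no measured pair here shows the effect of such a swap, so the expectation is only a modest step, if any, in this assay, with a slight lean upward. The step from compound 2 to compound 4 is estimated at a number 0.29 log units higher from compound 2 to compound 4 (within the scatter). Compound 4 is thus expected to give about 6.7, within 6 to 7.4.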

Compound 4, logarithm of the reciprocal of the active concentration, log(1/C): 7.94
Compound 4: the middle estimate sits 1.24 log units below what was measured, and the stated range ends below it.
By their numbers in this assay, from the lowest: compound 2; then compound 3; then compounds 4 and 1 (each within the scatter of the next).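

Putting fluoro in place of hydroxy(phenyl)methyl on this aromatic carbon gives a number 1.53 log units higher from compound 2 to compound 4 (beyond the scatter) in this assay and so shows that a high number here does not need a large group at this place. A single fluorine atom is enough. Nothing measured explains the size of this step. The swap removes the phenyl ring and the hydroxy group together, so their separate contributions cannot be told apart. As far as these compounds go, how a chlorine, a methyl or an amine on this carbon would compare with fluoro remains open.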